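From compound 3 to compound 4: a longer chain

The compounds below may be only part of what the source reports. "The series", "measured", "known", "first", "only" and "open" are said of these compounds alone.

In a functional assay on MDA-MB-231 cells (Homo sapiens) for antiproliferative activity, with a stated time of 4 days (on this read-out lower numbers stand for stronger inhibition and higher numbers for weaker inhibition), three compounds have been measured:
compound 1 `COc1ccc(-c2[nH]c3ccc(OC)cc3c2C=C(C#N)C#N)cc1` gives 590 nM
compound 2 `COc1ccc(-c2[nH]c3ccc(C)cc3c2C=C(C#N)C#N)cc1` gives 280 nM
compound 3 `CCCCCc1ccc2[nH]c(-c3ccc(OC)cc3)c(C=C(C#N)C#N)c2c1` gives 42 nM

Compound 3 has the lowest number of the three, and its steps to both others lie beyond the scatter. The data show a 6.7-fold lower number from compound 2 to compound 3 (0.82 log units; beyond the scatter) as its smallest gap and a 14-fold lower number from compound 1 to compound 3 (1.15 log units; beyond the scatter) as its largest one.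

Compound 4 `CCCCCCc1ccc2[nH]c(-c3ccc(OC)cc3)c(C=C(C#N)C#N)c2c1` is still unmeasured and differs from compound 3 by methyl in place of hydrogen on a saturated chain carbon, five bonds along the chain from an aromatic carbon in a single place: methyl in place of hydrogen on a saturated chain carbon, five bonds along the chain from an aromatic carbon. The closest evidence is a 6.7-fold lower number from compound 2 to compound 3 (0.82 log units; beyond the scatter) with butyl in place of hydrogen on the same chain, a modest step. Both a 2.1-fold lower number from compound 1 to compound 2 (0.32 log units; beyond the scatter) and a 14-fold lower number from compound 1 to compound 3 (1.15 log units; beyond the scatter) replace methoxy and so bear on this change less directly. For the measured compounds named here, no measured step adds a single methyl to this chain, and nothing shows how far the fall in the numbers runs on.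

Set against a 6.7-fold lower number from compound 2 to compound 3 (0.82 log units; beyond the scatter) with its butyl, a single methyl is a much smaller addition, so in this assay no step beyond the scatter is expected, only a slight lean toward a lower number. The estimate expects a 1.2-fold lower number from compound 3 to compound 4 (0.08 log units; within the scatter) in this read-out. For compound 4 the estimated value is 35 nM with 15 nM to 85 nM as the expected span.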

Compound 4, half-maximal inhibitory concentration: 46 nM
Compound 4: the middle estimate sits 1.3-fold (0.12 log units) below what was measured, within the range that was stated.
By their numbers in this assay, from the lowest: compounds 3 and 4 (each within the scatter of the next); then compound 2; then compound 1.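

In this assay, the added methyl, on a saturated chain carbon, five bonds along the chain from an aromatic carbon, turns the pentyl chain of compound 3 into the hexyl chain of compound 4 and gives a 1.1-fold higher number from compound 3 to compound 4 (0.04 log units; within the scatter), so this extension leaves the number within the scatter and shows that the fall seen on reaching pentyl does not continue measurably at this chain length. The hexyl chain still keeps the clear advantage over the smaller groups at this place on the shared core, with a 6.1-fold lower number from compound 2 to compound 4 (0.78 log units; beyond the scatter) against the methyl and a 13-fold lower number from compound 1 to compound 4 (1.11 log units; beyond the scatter) against the methoxy, and these gaps are close to those already seen for compound 3. Nothing available here explains why this added methyl leaves the number within the scatter.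

The compounds shown leave open whether a longer chain, such as heptyl or octyl, would keep these numbers or lose them, and what a branched chain or an amine or carboxylic acid at the chain end would do. They also leave open where along the ethyl, propyl and butyl chains the fall from compound 2 to compound 3 takes place.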